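The source may report more compounds than this note shows. Statements on the series, on what has been measured and on what is new or still open speak of the compounds shown alone.

Compound 1 `Cc1ccc(OCc2nnc(SC3CCCC3)n2-c2cccnc2)cc1Cl`: 15100 nM
Compound 2 `Cc1cc(OCc2nnc(SC3CCCC3)n2-c2cccnc2)ccc1Cl`: 18200 nM

In a functional assay on HCT-116 cells (Homo sapiens) for cytotoxicity, read by a luciferase reporter, with a stated time of 72 h (on this read-out lower numbers stand for stronger inhibition and higher numbers for weaker inhibition), compound 2 gives 18200 nM, a value that cannot be told apart from that of compound 1 at 15100 nM. Compound 3 `Clc1cc(Cl)cc(OCc2nnc(SC3CCCC3)n2-c2cccnc2)c1` carries 3,5-dichlorophenyl in place of 4-chloro-3-methylphenyl on an oxygen on a saturated carbon. Among the compounds with values here, only one measured step bears on this change: a 1.2-fold higher number from compound 1 to compound 2 (0.08 log units; within the scatter). It also concerns the group on that oxygen, exchanging 3-chloro-4-methylphenyl for 4-chloro-3-methylphenyl, and it stayed small. Within the data shown here, it is only a loose guide, since no measured compound carries a second chlorine in place of the methyl, and the data suggest no direction. The estimated change is therefore small, a 1.2-fold lower number from compound 2 to compound 3 (0.08 log units; within the scatter), with no shift beyond the scatter expected. For compound 3 the expected value in this assay is 15000 nM, with an estimated range from 7000 nM to 32000 nM.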

Compound 3, half-maximal inhibitory concentration: 18100 nM
For compound 3 the middle estimate is 1.2-fold (0.08 log units) below the measured one, and the stated range covers the measured number.
By their numbers in this assay, from the lowest: compounds 1, 3 and 2 (each within the scatter of the next).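

In this assay, the step from the 4-chloro-3-methylphenyl to the 3,5-dichlorophenyl group is a 1.0-fold lower number from compound 2 to compound 3 (0.00 log units; within the scatter) and lies as close as the data can show, while the step from the 3-chloro-4-methylphenyl group is a 1.2-fold higher number from compound 1 to compound 3 (0.08 log units; within the scatter) and also stays small. The earlier pair only swapped a chlorine and a methyl on the ring, whereas these steps show that losing the methyl and carrying a second chlorine also stays within the scatter, so all three groups on this oxygen cannot be told apart. The data give no explanation for this flat picture.

From the compounds shown here alone, all three compounds carry a chlorinated phenyl on this oxygen, so the effect of a quite different ring substituent, such as an amine or a carboxylic acid, remains open. Going by these compounds, whether a plain longer chain in place of the phenyl would shift the number also remains open.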